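The compounds below may be only part of what the source reports. "The series", "measured", "known", "first", "only" and "open" are said of these compounds alone.

Measured so far:

Compound 1 `COc1c(F)c(N)c2c(=O)cc(-c3ccc(N)c(F)c3)oc2c1F` gives 34000 nM in a functional assay on HeLa cells (Homo sapiens) for cytotoxicity, read by neutral red uptake, with a stated time of 3 days; a lower number here means a stronger inhibitor, a higher number a weaker inhibitor.
Compound 2 `CCCCCC(=O)OCc1c(F)c(N)c2c(=O)cc(-c3ccc(N)c(F)c3)oc2c1F` gives 34000 nM in this assay.
Compound 3 `CCCCCCCCCC(=O)OCc1c(F)c(N)c2c(=O)cc(-c3ccc(N)c(F)c3)oc2c1F` is reported only as a limit of the assay, > 100000 nM.

Compound 1 thus stands level with compound 2 at the digits shown, and the third value on record for this series is a limit rather than a number. Compound 4 `CN(C)CCCC(=O)OCc1c(F)c(N)c2c(=O)cc(-c3ccc(N)c(F)c3)oc2c1F` is the unmeasured member; it differs from compound 1 in one place: (((3-(dimethylamino)propyl)carbonyl)oxy)methyl in place of methoxy on an aromatic carbon. Going by the values given here, two measured steps bear on this change. The first, no change at the digits printed from compound 1 to compound 2 (within the scatter), shows that replacing methoxy by a chain carrying a carbonyl and an oxygen left the number where it was. The second, an at least 2.9-fold higher number from compound 2 to compound 3 (0.46 log units; beyond the scatter), shows that lengthening that chain pushed the number up to the limit of the assay (the limit of > 100000 nM in this assay, at which 1 of the 3 values shown sits). Compound 4 carries a chain of a length closer to compound 2 than to compound 3, with a dimethylamino group at its end instead of further carbons. On that basis, the change from compound 1 to compound 4 is expected to stay within the scatter, no change at the digits printed from compound 1 to compound 4 (within the scatter). Compound 4 is therefore estimated at 34000 nM, with a likely range from 15000 nM to 90000 nM.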

Compound 4, half-maximal inhibitory concentration: 4500 nM
Estimate against measurement, compound 4: 7.6-fold (0.88 log units) above; the whole stated range lies above it.
By their numbers in this assay, from the lowest: compound 4; then compounds 1 and 2 (each within the scatter of the next). At a limit, above all of these: compound 3.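

Going by these compounds alone, until now, changes to the ester chain at this position had either left the number in this assay where it was or pushed it up, so the dimethylamino end is the first change here to lower it, giving a 7.6-fold lower number from compound 1 to compound 4 (0.88 log units; beyond the scatter). Changing only the end of the chain, dimethylamino in place of ethyl, gives a 7.6-fold lower number from compound 2 to compound 4 (0.88 log units; beyond the scatter), and compound 2 carries the same ester link yet stands level with compound 1, so the ester link alone does not go with the lower number. Dimethylamino in place of hexyl gives an at least 22-fold lower number from compound 3 to compound 4 (1.34 log units; beyond the scatter), a step that rests on a limit of the assay rather than a number for compound 3: the limit of > 100000 nM in this assay, at which 1 of the 4 values shown sits.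

The compounds shown leave open whether the lower number belongs to dimethylamino itself or would also follow from a primary amine, a morpholine or a carboxylic acid at the same chain end. They also leave open how much the chain length matters, which a shorter or a longer chain ending in dimethylamino would help to settle.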